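A Halogen Swap in a Level Sulfonamide Series

The compounds below may be only part of what the source reports. "The series", "measured", "known", "first", "only" and "open" are said of these compounds alone.

Three sulfonamides that share one core have so far been tested in a functional assay on cells (leukaemia cell line, Homo sapiens) for inhibition, read by sulforhodamine B assay, with a stated time of 48 h (on this read-out lower numbers stand for stronger inhibition of growth and higher numbers for weaker inhibition of growth), with closely matching results. There compound 1 (`O=S(=O)(Nc1ccc(Cl)cc1Cl)c1ccc(-c2cnc(C3CC3)o2)cc1`) gives 481 nM and compound 2 (`O=S(=O)(Nc1cccc(Cl)c1)c1ccc(-c2cnc(C3CC3)o2)cc1`) gives 477 nM while compound 3 (`O=S(=O)(Nc1ccc(Br)c(Cl)c1)c1ccc(-c2cnc(C3CC3)o2)cc1`) gives 491 nM as its reading. Compound 3 therefore stands level with the other two, inside the ordinary scatter of repeated measurements.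

Compound 4 (`O=S(=O)(Nc1ccc(F)cc1F)c1ccc(-c2cnc(C3CC3)o2)cc1`) follows from compound 3 with 2,4-difluorophenyl in place of 4-bromo-3-chlorophenyl on a sulfonamide nitrogen. Three measured changes to this same ring bear on that swap. They are a 1.0-fold lower number from compound 1 to compound 2 (0.00 log units; within the scatter) and a 1.0-fold higher number from compound 1 to compound 3 (0.01 log units; within the scatter) and also a 1.0-fold higher number from compound 2 to compound 3 (0.01 log units; within the scatter) and all of them lie within the scatter. Moving chlorine and bromine around this ring has thus left the number unmoved in these three compounds. None of them carries fluorine, however, so the forecast reaches beyond what has been measured and needs a generous range.

The expected step is a 1.0-fold lower number from compound 3 to compound 4 (0.00 log units; within the scatter) and nothing beyond the scatter is foreseen. For compound 4 the estimated value is 490 nM with an expected range from 250 nM to 950 nM in this test.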

Compound 4, concentration for 50% growth inhibition: 356 nM
The estimate for compound 4 lay 1.4-fold (0.14 log units) above the measured number, and the stated range covers the measured number.
By their numbers in this assay, from the lowest: compounds 4, 2, 1 and 3 (each within the scatter of the next).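

In this assay, among these compounds, the 2,4-difluorophenyl group brings fluorine onto the sulfonamide nitrogen's ring for the first time, and compound 4 stays level with all three earlier compounds, with a 1.4-fold lower number from compound 3 to compound 4 (0.14 log units; within the scatter) and a 1.3-fold lower number from compound 2 to compound 4 (0.13 log units; within the scatter) and also a 1.4-fold lower number from compound 1 to compound 4 (0.13 log units; within the scatter) as the three steps. The earlier compounds shown here showed this only for chlorine and bromine, so across these four compounds the aromatic group at this place can carry fluorine, chlorine or bromine, and no compound here goes against that level picture. No supporting measurement accompanies these readings, so nothing here explains why the four compounds agree.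

Among the compounds shown here, every group at this place so far is a phenyl ring carrying only halogens, so it remains open whether the reading would hold with an amine, a carboxylic acid or a methoxy group on that ring, or with a plain phenyl ring. As far as these compounds go, a longer chain between the sulfonamide nitrogen and the ring, or an alkyl chain in place of the ring, is equally open, and either could show how much change this place allows before the reading moves beyond the scatter.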